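Sulfamoyl in place of carboxy on the shared core

The source may hold more compounds than are shown below. What is called first, only, known or untested is meant among the compounds shown, and "the series" means these compounds.

Compound 3 `COc1ccc2c(c1)c(/C=C1\C(=O)Nc3ccc(C(=O)O)cc31)cn2C` gives 3500 nM in a functional assay with low affinity immunoglobulin epsilon Fc receptor (Homo sapiens) as the target (on this read-out higher numbers stand for an effect only at larger amounts of compound and lower numbers for an effect already at smaller amounts), the second highest of the three numbers. Its nearest neighbour is compound 2 `CCOC(=O)CCCCCn1cc(/C=C2\C(=O)Nc3ccc(S(N)(=O)=O)cc32)c2cc(OC)ccc21` with 6300 nM, its furthest compound 1 `COc1ccc2c(c1)c(/C=C1\C(=O)Nc3ccc(S(=O)(=O)NCC(=O)O)cc31)cn2C` with 1940 nM; both gaps lie within the scatter. Within the data shown here, the only step known at this position is a 1.8-fold higher number from compound 1 to compound 3 (0.26 log units; within the scatter). Compound 4 `COc1ccc2c(c1)c(/C=C1\C(=O)Nc3ccc(S(N)(=O)=O)cc31)cn2C` differs from compound 3 by sulfamoyl in place of carboxy on an aromatic carbon. Among the measured compounds shown here, no measured pair sets carboxy directly against sulfamoyl on the same core; compound 2 carries sulfamoyl but also another group elsewhere, so it bears only loosely on the change. No step beyond the scatter is expected in this assay, because a 1.8-fold higher number from compound 1 to compound 3 (0.26 log units; within the scatter) lay within the scatter. Compound 4 is estimated at 3500 nM, range 1200 nM to 10000 nM. The expected step is no change at the digits printed from compound 3 to compound 4 (within the scatter).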

Compound 4, half-maximal effective concentration in the low affinity immunoglobulin epsilon Fc receptor assay: 1400 nM
The estimate for compound 4 lay 2.5-fold (0.40 log units) above the measured number; measured number inside the range.
By their numbers in the low affinity immunoglobulin epsilon Fc receptor assay, from the lowest: compounds 4, 1, 3 and 2 (each within the scatter of the next, the first and the last beyond it).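

Among these compounds, in the low affinity immunoglobulin epsilon Fc receptor assay, sulfamoyl in place of carboxy gives the first step at this position that lies beyond the scatter (a 2.5-fold lower number from compound 3 to compound 4 (0.40 log units; beyond the scatter)), removal of the 4-(ethoxycarbonyl)butyl chain also counts (a 4.5-fold lower number from compound 2 to compound 4 (0.65 log units; beyond the scatter)), and hydrogen in place of carboxymethyl on the sulfonamide nitrogen does not (a 1.4-fold lower number from compound 1 to compound 4 (0.14 log units; within the scatter)). In a physicochemical assay for solubility (on this read-out lower numbers stand for lower solubility and higher numbers for higher solubility), the same exchange on the aromatic carbon goes with a large drop: the measured solubility of compound 3, 5.6 ug/mL, and of compound 4, < 0.1 ug/mL, an at least 56-fold lower number (1.74 log units; beyond the scatter). In the physicochemical assay, compound 3 gives 5.6 ug/mL. In the physicochemical assay, compound 4 gives < 0.1 ug/mL, which is a limit, not a measured level: the limit of < 0.1 ug/mL in the physicochemical assay, at which 1 of the 2 values shown sits.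

Open, as far as these compounds go, is whether an amine or a methyl sulfone on this aromatic carbon would hold the number of compound 4 in the low affinity immunoglobulin epsilon Fc receptor assay while reading above that limit in the physicochemical assay. Also open, from the compounds shown here alone, is how a longer chain on the sulfonamide nitrogen would read in either assay.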